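Ethoxy added to compound 1: expected effect on growth

The source may report more compounds than this note shows. Statements on the series, on what has been measured and on what is new or still open speak of the compounds shown alone.

Values so far in a functional assay on HCC 2998 cells (Homo sapiens) for antiproliferative activity (on this read-out higher numbers stand for weaker inhibition of growth and lower numbers for stronger inhibition of growth), for the three measured compounds
compound 1 `COc1ccc(-c2nc3cc(F)ccc3s2)cc1` gives 12400 nM 
compound 2 `Oc1ccc(-c2nc3cc(F)ccc3s2)cc1O` gives 1640 nM 
compound 3 `COCOc1ccc(-c2nc3cc(F)ccc3s2)cc1OC` gives 53500 nM 

Compound 1 holds the second highest of the three numbers, with compound 3 higher and compound 2 lower, and both gaps lie beyond the scatter. Next to be measured is compound 4 `CCOc1cc(-c2nc3cc(F)ccc3s2)ccc1OC`, and its difference from compound 1 is ethoxy in place of hydrogen on an aromatic carbon (ethoxy in place of hydrogen on an aromatic carbon, ortho to a methoxy group and meta to a large group). Within the data shown here, no measured pair isolates this change, so any expectation is indirect. Like compound 4, compound 3 has no free hydroxy group and gives 53500 nM in this assay while the hydroxy-bearing compound 2 gives 1640 nM on the same read-out. A small rise in the number, not beyond the scatter, is therefore expected in this assay for this change. The estimated change is a 1.6-fold higher number from compound 1 to compound 4 (0.21 log units; within the scatter) and it points towards weaker inhibition of growth. For compound 4 the expected value is 20000 nM with an estimated range from 6000 nM to 60000 nM on present data.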

Compound 4, concentration for 50% growth inhibition: 3320 nM
The estimate for compound 4 lay 6.0-fold (0.78 log units) above the measured number; the measured number lies below the stated range.
By their numbers in this assay, from the lowest: compound 2; then compound 4; then compound 1; then compound 3.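

In this assay, ethoxy in place of hydrogen on an aromatic carbon, ortho to a methoxy group and meta to a large group, gives a 3.7-fold lower number from compound 1 to compound 4 (0.57 log units; beyond the scatter) and so points towards stronger inhibition of growth. Among these compounds, this is the first step that isolates one change, and it shows that this position on the core of compound 1 accepts ethoxy with a gain rather than a loss; compound 4 achieves this without a free hydroxy group. The data offer no measured explanation for this gain.

A single step cannot show whether the gain belongs to ethoxy specifically or to any substituent at this position. A hydroxy group, a methoxy group, a longer chain such as butoxy, or an amine at the same carbon would separate these readings.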